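A few compounds are considered here, and "the series" means these few. Any claim that something is new, unique, unknown or untested is made for them only; others in the source may bear on it.

Compound 1 `COc1cccc(CNCc2c(C(=O)O)n(Cc3ccccc3)c3cc(C(C)C)ccc23)c1` gives 5090 nM in a functional assay on SNU-387 cells (Homo sapiens) for antiproliferative activity, read by MTT assay, with a stated time of 72 h; on this read-out higher numbers stand for weaker inhibition and lower numbers for stronger inhibition. Among the compounds with values here, that is the lowest of the three numbers measured so far, though compound 3 `COc1ccc(Cn2c(C(=O)O)c(CNCc3ccc(O)c(OC)c3)c3ccc(C)cc32)cc1`, at 6150 nM, lies within the scatter of it, so these two cannot be placed in order. Compound 2 `COc1ccc(Cn2c(C(=O)O)c(CN(C)Cc3cccc(OC)c3)c3ccc(C)cc32)cc1`, at 20100 nM, stands clearly further up. Within the data shown here, the only single-point step among the measured compounds is a 3.3-fold lower number from compound 2 to compound 3 (0.51 log units; beyond the scatter), and it concerns the amine on the saturated chain carbon rather than the benzyl group on the core nitrogen. Compound 4 `COc1cccc(CNCc2c(C(=O)O)n(Cc3ccccc3F)c3cc(C(C)C)ccc23)c1` is compound 1 with one change: fluoro in place of hydrogen on an aromatic carbon, which read one bond further out is benzyl to 2-fluorobenzyl. Among the measured compounds shown here, no measured pair shows this change, so nothing among the numbers in hand speaks for or against it, and the step from compound 2 to compound 3 does not bear on it. The analyst therefore expects no step beyond the scatter in this assay, which is a 1.1-fold lower number from compound 1 to compound 4 (0.05 log units; within the scatter). For compound 4 he estimates 4500 nM, within a range from 1800 nM to 11000 nM.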

Compound 4, half-maximal inhibitory concentration: 6090 nM
Compound 4: middle estimate off by 1.4-fold (0.13 log units), on the low side; the measured number falls inside the stated range.
By their numbers in this assay, from the lowest: compounds 1, 4 and 3 (each within the scatter of the next); then compound 2.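

Within the data shown here, the change from benzyl to 2-fluorobenzyl is the first measured change on this ring, and in this assay it amounts to a 1.2-fold higher number from compound 1 to compound 4 (0.08 log units; within the scatter) and so cannot be told apart from repeat measurements of a single compound. Fluoro is therefore accepted on this aromatic carbon of compound 1 without a readable gain or loss, although this rests on a single pair of compounds with an isopropyl-bearing core and a single amine side chain. No independent measurement is available to explain the result or to tie it to any property of the fluoro group.

This one pair does not show whether a larger substituent such as chloro, methoxy or trifluoromethyl on the same carbon would also leave the number within the scatter, or whether fluoro would do so on the other carbons of the ring. Every compound shown also carries the carboxylic acid, so the effect of an ester or an amide in its place remains open.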